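This account rests on a few compounds, and the source may have more. Where it says the series, first, only, none or still open, it means among the compounds named here.

Three compounds have been measured in an ADME assay on microsomes from liver (Mus musculus, strain NMRI) for metabolic stability, tested at 2.5 uM; a higher number here means faster removal of the compound, a lower number slower removal:

Compound 1, `N#Cc1cccc2c1nnn2Cc1ccc(-c2ccc(Cl)cc2F)nc1`, gives 1.6 mL/min/g.
Compound 2, `Fc1cc(Cn2nnc3c(Br)cccc32)ccc1Cl`, gives 2.2 mL/min/g.
Compound 3, `Clc1cccc2c1nnn2CC1CC1`, gives 5.7 mL/min/g.

Compound 3 stands highest of the three numbers, meaning it is removed fastest in this assay. Its nearest neighbour is compound 2, whose number is lower by a margin beyond the usual scatter, and compound 1 lies further still below it. Among the measured compounds shown here, none of these three compounds differs from another in only one place, so there is no measured single step to lean on.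

Compound 4, `FC(F)(F)c1cccc2c1nnn2CC1CC1`, is the next compound to be measured. It differs from compound 3 in one place: trifluoromethyl in place of chloro on an aromatic carbon. For the measured compounds named here, with no measured step of this kind among the three compounds, only a cautious guess is possible. The change from compound 3 to compound 4 is expected to be small, toward slower removal, at the edge of the scatter: a 1.6-fold lower number from compound 3 to compound 4 (0.21 log units; within the scatter). Compound 4 is therefore expected to give about 3.5 mL/min/g in this assay, with a range from 1.8 mL/min/g to 7 mL/min/g.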

Compound 4, intrinsic clearance in a liver preparation (reported as CLH), per the amount of preparation that the assay uses: 1.4 mL/min/g
For compound 4 the middle estimate is 2.5-fold (0.40 log units) above the measured one; measured number below the stated range.
By their numbers in this assay, from the lowest: compounds 4, 1 and 2 (each within the scatter of the next); then compound 3.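

In this assay, trifluoromethyl in place of chloro on this aromatic carbon gives a 4.1-fold lower number from compound 3 to compound 4 (0.61 log units; beyond the scatter). Among the compounds shown here, this is the first step in the set that changes one place only, and it shows that the group on this carbon can, by itself, move the number beyond the usual scatter, here toward slower removal. Nothing available explains why this step has the size it has.

From the compounds shown here alone, this is a single step on a single shared core, so it remains open whether the same change would lower the number as much in compounds carrying the larger groups of compound 1 or compound 2. Also open, going by these compounds, is where a methyl or a methoxy on this same carbon would fall relative to chloro and trifluoromethyl.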